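Compound 3 to compound 4: a triazole on the side arm

A few compounds are considered here, and "the series" means these few. Any claim that something is new, unique, unknown or untested is made for them only; others in the source may bear on it.

In a functional assay on SMMC-7721 cells (Homo sapiens) for antiproliferative activity, read by MTT assay, with a stated time of 48 h (a lower number here means a stronger inhibitor, a higher number a weaker inhibitor), compound 1 (`CC(=O)OC/C1=C/C[C@](C)(CCC=C(C)C)/C=C/[C@@H](OC(=O)C=C(C)C)[C@](C)(O)/C=C/C1=O`) gives 2950 nM and compound 2 (`CC(C)=CCC[C@]1(C)/C=C/[C@@H](OC(=O)C=C(C)C)[C@](C)(O)/C=C/C(=O)/C(CN2CCN(C)CC2)=C\C1`) gives 2940 nM while compound 3 (`CC(C)=CCC[C@]1(C)/C=C/[C@@H](OC(=O)C=C(C)C)[C@](C)(O)/C=C/C(=O)/C(COC(=O)c2ccc([N+](=O)[O-])cc2)=C\C1`) gives 2560 nM so compound 3 stands within the scatter of both other compounds.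

Compound 4 (`CC(C)=CCC[C@]1(C)/C=C/[C@@H](OC(=O)C=C(C)C)[C@](C)(O)/C=C/C(=O)/C(Cn2cc(CO)nn2)=C\C1`) carries 4-(hydroxymethyl)-1H-1,2,3-triazol-1-yl in place of ((4-nitrophenyl)carbonyl)oxy on a saturated chain carbon bound to a double-bonded ring carbon.

All three measured steps concern this same place. The change of 4-methylpiperazin-1-yl for acetoxy gives a 1.0-fold lower number from compound 1 to compound 2 (0.00 log units; within the scatter) as its result. The change of 4-nitrophenyl for methyl on a carbonyl carbon gives a 1.2-fold lower number from compound 1 to compound 3 (0.06 log units; within the scatter) as its result. The direct exchange of these two larger groups gives a 1.1-fold lower number from compound 2 to compound 3 (0.06 log units; within the scatter) as its result. Each step lies within the scatter, and none of the three compounds goes against this. No triazole has yet been measured at this place, so these steps are only a guide and the range is kept wide.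

The estimated change is a 1.1-fold higher number from compound 3 to compound 4 (0.04 log units; within the scatter) and no step beyond the scatter is expected in either direction. For compound 4 the expected value is 2800 nM with an estimated range from 1300 nM to 6000 nM at this stage of the series.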

Compound 4, half-maximal inhibitory concentration: 3560 nM
The estimate for compound 4 lay 1.3-fold (0.10 log units) below the measured number; measured number inside the range.
By their numbers in this assay, from the lowest: compounds 3, 2, 1 and 4 (each within the scatter of the next).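

In this assay, 4-(hydroxymethyl)-1H-1,2,3-triazol-1-yl on a saturated chain carbon bound to a double-bonded ring carbon stays within the scatter of all three earlier groups (a 1.4-fold higher number from compound 3 to compound 4 (0.14 log units; within the scatter); a 1.2-fold higher number from compound 2 to compound 4 (0.08 log units; within the scatter); a 1.2-fold higher number from compound 1 to compound 4 (0.08 log units; within the scatter)). This extends the flat picture at this place to a five-membered aromatic ring with 3 hetero atoms and to a group with 1 hydrogen-bond donor: acetoxy, 4-methylpiperazin-1-yl, ((4-nitrophenyl)carbonyl)oxy and the triazole show no step beyond the scatter, and none of the four compounds goes against this. No supporting data are available to explain this flat result.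

No group shown so far moves the number beyond the scatter, so it remains open whether any change at this place can do so, or whether the shared core alone sets the level seen here. A carboxylic acid, a primary amine or a longer alkyl chain at this same place would test how far this flat picture extends.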